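The source may report more compounds than this note shows. Statements on the series, on what has been measured and on what is new or still open speak of the compounds shown alone.

Measured in a functional assay on EOL1 cells (Homo sapiens) for inhibition, read by fluorescence, with a stated time of 72 h; a lower number here means a stronger inhibitor of growth, a higher number a weaker inhibitor of growth:
Compound 1 `N[C@H]1CC[C@H](Nc2nc(Nc3ccc(Cl)cc3)c3ncn(C4CCCCC4)c3n2)CC1`: 140 nM
Compound 2 `COc1ccc(Cn2cnc3c(Nc4cccc(Cl)c4)nc(N[C@H]4CC[C@H](N)CC4)nc32)cc1`: 530 nM
Compound 3 `CCCCCCn1cnc2c(Nc3ccc(O)cc3)nc(N[C@H]3CC[C@H](N)CC3)nc21`: 190 nM

Compound 2 has the highest number of the three, which makes it the weakest inhibitor of growth here, and its steps to both others lie beyond the scatter. Compound 4 `CCCCn1cnc2c(Nc3cccc(Cl)c3)nc(N[C@H]3CC[C@H](N)CC3)nc21` differs from it in one place: propyl in place of 4-methoxyphenyl on a saturated chain carbon bound to an aromatic nitrogen. Within the data shown here, no measured pair isolates this change. Compound 3, with a hexyl chain there, gives 190 nM, and compound 1, with cyclohexyl there, gives 140 nM, though both also differ elsewhere. A modest fall in this assay is therefore expected, estimated as a 2.0-fold lower number from compound 2 to compound 4 (0.31 log units; beyond the scatter). For compound 4 the estimated value is 260 nM, with an expected range of 110 nM to 620 nM.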

Compound 4, concentration for 50% growth inhibition: 160 nM
Beside the measured number, compound 4's estimate is 1.6-fold (0.21 log units) above it; measured number inside the range.
By their numbers in this assay, from the lowest: compounds 1, 4 and 3 (each within the scatter of the next); then compound 2.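

In this assay, among these compounds, this is the only pair that differs solely at this place: propyl in place of 4-methoxyphenyl on a saturated chain carbon bound to an aromatic nitrogen gives a 3.3-fold lower number from compound 2 to compound 4 (0.52 log units; beyond the scatter) and so shows that the aromatic ring is not needed here for growth inhibition. Nothing at hand explains the size of this step.

Still open, on these data alone, is whether the ring or its methoxy group accounts for the step, which plain benzyl would separate. Also open, as far as these compounds go, is how ethyl, or a chain ending in an amine, would read at this place.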